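The source may report more compounds than this note shows. Statements on the series, on what has been measured and on what is new or still open speak of the compounds shown alone.

Compound 1 `COc1cc(-c2cc(/C=C/C(=O)c3ccc(N)cc3)[nH]n2)cc(OC)c1OC` gives 2850 nM in a functional assay on SK-MEL-2 cells (Homo sapiens) for inhibition, read by sulforhodamine B assay, with a stated time of 48 h; on this read-out higher numbers stand for weaker inhibition of growth and lower numbers for stronger inhibition of growth. Compound 2 `COc1ccc(-c2cc(/C=C/C(=O)c3ccc(N)cc3)[nH]n2)cc1OC` differs from compound 1 by hydrogen in place of methoxy on an aromatic carbon; in this assay compound 2 gives 8440 nM; the step is a 3.0-fold higher number from compound 1 to compound 2 (0.47 log units; beyond the scatter). Compound 3 `COc1cc(C(=O)/C=C/c2cc(-c3cc(OC)c(OC)c(OC)c3)n[nH]2)cc(OC)c1OC` gives 1960 nM in this assay; the difference between the core of compound 3 and the core of compound 1 is not broken down here. Compound 4 `COc1ccc(-c2cc(/C=C/C(=O)c3cc(OC)c(OC)c(OC)c3)[nH]n2)cc1OC` differs from compound 3 by hydrogen in place of methoxy on an aromatic carbon, and the description of the place matches word for word that of the change from compound 1 to compound 2, so it is taken as the same kind of change. Going by the values given here, because a 3.0-fold higher number from compound 1 to compound 2 (0.47 log units; beyond the scatter) is the single measured instance of this change, compound 4 is expected to move by a 3.0-fold higher number from compound 3 to compound 4 (0.48 log units; beyond the scatter) in this assay, an expectation resting on one pair only. Compound 4 is therefore estimated at 5900 nM, with a range from 2500 nM to 14000 nM.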

Compound 4, concentration for 50% growth inhibition: 2690 nM
Beside the measured number, compound 4's estimate is 2.2-fold (0.34 log units) above it, within the range that was stated.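

The second instance of hydrogen in place of methoxy on an aromatic carbon is a 1.4-fold higher number from compound 3 to compound 4 (0.14 log units; within the scatter) in this assay, so on this core the change does not separate from the scatter. Set beside the first instance, the step does not differ from it: the same change on two cores in this assay, a 3.0-fold higher number (0.47 log units; beyond the scatter) from compound 1 to compound 2 and a 1.4-fold higher number (0.14 log units; within the scatter) from compound 3 to compound 4, 2.2-fold (0.33 log units) apart, within the scatter of two such steps. Two pairs are compatible with the change carrying over between these cores, but they neither fix a common size for it nor exclude some dependence on the core.

Only methoxy and hydrogen appear at this place in the compounds shown, which leaves open how a hydroxyl, a fluorine or a longer chain such as ethoxy would read there. On these data alone, whether the change behaves alike on a third core also remains open.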